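The compounds below may be only part of what the source reports. "The series", "measured", "known", "first", "only" and "open" are said of these compounds alone.

Measured so far:
Compound 1, `CSc1nc(SC)c2ncn([C@@H]3C[C@@H](O)[C@H](CO)O3)c2n1`: in a functional assay on K562 cells (Homo sapiens) (on this read-out lower numbers stand for stronger inhibition and higher numbers for weaker inhibition), compound 1 gives > 300 uM, which is a limit of the assay.
Compound 2, `CNc1nc(SC)nc2c1ncn2[C@@H]1C[C@@H](O)[C@H](CO)O1`: compound 2 gives > 300 uM, again a limit of the assay.
Compound 3, `CN(C)c1nc(Br)nc2c1ncn2[C@@H]1C[C@@H](O)[C@H](CO)O1`: compound 3 gives > 300 uM, also a limit of the assay.

Compound 3 therefore stands where every measured compound stands, at the edge of what this assay can report, (the limit of > 300 uM in this assay, at which 3 of the 3 values shown sit). Going by the values given here, no compound has a number that could be placed above or below another. Among the compounds with values here, the only step between compounds that differ in one place, a step that the two limits leave unreadable from compound 1 to compound 2, yields no size, since both ends are limits.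

The next compound, compound 4, `CSc1nc(N(C)C)c2ncn([C@@H]3C[C@@H](O)[C@H](CO)O3)c2n1`, differs from compound 3 in this way: methylsulfanyl in place of bromo on an aromatic carbon. Within the data shown here, no measured step involves an exchange of bromo for methylsulfanyl, and the one step that does involve methylsulfanyl is unreadable. The evidence thus gives no direction and no size to build on; it only shows that three close relatives all sit at the limit.

The step from compound 3 to compound 4 is expected to be a number no higher from compound 3 to compound 4 (the limit leaves the size open), that is, no readable change. Compound 4 is accordingly estimated at 300 uM, with a range from 100 uM to 1000 uM, most likely reported as a limit once more.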

Compound 4, concentration for 50% inhibition: > 300 uM
Compound 4: only a limit was reported; the forecaster's own chance of this, stated with the estimate: 85%; the middle value sits exactly at the limit.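

Compound 4 ends up where compound 1, compound 2 and compound 3 already stand, so none of the steps joining it to them can be read: the limit of > 300 uM in this assay, at which 4 of the 4 values shown sit.

The compounds shown leave open whether any exchange on the shared core gives a real number in this assay at all, and in which direction and how far each exchange would move it.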